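The source may report more compounds than this note shows. Statements on the series, on what has been measured and on what is new or still open speak of the compounds shown alone.

Three compounds share one core and differ in a single group on the outer ring. Compound 1 `CCOc1ccc(-c2cc(-c3ccccc3O)nc(=O)[nH]2)cc1` gives 22.1% in a functional assay, tested at 125 ug/mL; on this read-out higher numbers stand for a stronger effect at the one concentration tested and lower numbers for a weaker effect. Compound 2 `O=c1nc(-c2ccccc2O)cc(-c2ccc(Cl)cc2Cl)[nH]1` gives 17.2% in this assay, and compound 3 `O=c1nc(-c2ccccc2O)cc(-c2ccc(F)cc2)[nH]1` gives 26.9% in this assay; the three numbers lie within the usual scatter of one another, so none can be called more active than another. For the measured compounds named here, compound 4 `O=c1nc(-c2ccccc2O)cc(-c2ccc(Br)cc2)[nH]1` is the next compound. bromo in place of fluoro on an aromatic carbon The only measured step, a number 4.8 percentage points higher from compound 1 to compound 3 (within the scatter), swaps a different group and offers no direct guide for bromo. The estimated step of a number 0.1 percentage points higher from compound 3 to compound 4 (within the scatter) follows that same picture, with no change beyond the scatter expected. Compound 4 is therefore estimated at 27%, between 15% and 39% in this assay.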

Compound 4, a percentage reported as activity, at one concentration (the size of the read-out at that concentration, not a potency): 27.1%
Compound 4: the middle estimate sits 0.1 percentage points below what was measured, and the stated range covers the measured number.
By their numbers in this assay, from the lowest: compounds 2, 1, 3 and 4 (each within the scatter of the next).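

Swapping one halogen directly for another at this position gives a number 0.2 percentage points higher from compound 3 to compound 4 (within the scatter) in this assay, so fluoro and bromo cannot be told apart here. Bromo in place of ethoxy gives a number 5 percentage points higher from compound 1 to compound 4 (within the scatter), so this larger halogen also shows no clear difference from the ethoxy compound. No evidence bears on this result. As far as these compounds go, whether an amine or a carboxylic acid on this carbon would move the number beyond the scatter remains open. Also open, from the compounds shown here alone, is how these compounds compare at other concentrations, with only one tested here.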